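The compounds below may be only part of what the source reports. "The series", "measured", "known", "first", "only" and "open" are said of these compounds alone.

Measured so far:
compound 1, `O=C(CCCCC1CCSS1)NCc1cn(CCCOc2ccc3cc(-c4ccc(Br)cc4)c(=O)oc3c2)nn1`, gives 63.3% in a functional assay on PC-12 cells (Rattus norvegicus) for cytotoxicity, read by MTT assay, with stated times of 3 h and 2 h, tested at 10 uM; on this read-out higher numbers stand for a stronger effect at the one concentration tested and lower numbers for a weaker effect
compound 2, `O=C(CCCCC1CCSS1)NCc1cn(CCCOc2ccc3cc(-c4ccc(Cl)c(Cl)c4)c(=O)oc3c2)nn1`, gives 49.6% in this assay
compound 3, `O=C(CCCCC1CCSS1)NCc1cn(CCCCCOc2ccc3cc(-c4ccc(Br)cc4)c(=O)oc3c2)nn1`, gives 48.4% in this assay

One substituent change is documented once within the measured set. The change 3,4-dichlorophenyl in place of 4-bromophenyl on an aromatic carbon gave a number 13.7 percentage points lower from compound 1 to compound 2 (beyond the scatter) in this assay. Compound 3 differs from compound 1 in the core; the difference between the two cores is not broken down here. In this assay compound 3 and compound 2 sit within the scatter of each other, while compound 1 stands beyond the scatter above compound 3.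

Compound 4, `O=C(CCCCC1CCSS1)NCc1cn(CCCCCOc2ccc3cc(-c4ccc(Cl)c(Cl)c4)c(=O)oc3c2)nn1`, is not yet measured. It is related to compound 3 by 3,4-dichlorophenyl in place of 4-bromophenyl on an aromatic carbon, the same change that relates compound 1 to compound 2, at the same place in the same surroundings. Among the compounds with values here, on the core of compound 3 a step of about the same size as the earlier one is expected, that is a number 13.4 percentage points lower from compound 3 to compound 4 (beyond the scatter), resting on the single documented step a number 13.7 percentage points lower from compound 1 to compound 2 (beyond the scatter). The starting point of that expected step is the value of compound 3, 48.4%. For compound 4 a value of 35% is estimated, with an expected range from 24% to 46%.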

Compound 4, a percentage reported as activity, at one concentration (the size of the read-out at that concentration, not a potency): 59.4%
For compound 4 the middle estimate is 24.4 percentage points below the measured one; measured number above the stated range.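

On the core of compound 3, 3,4-dichlorophenyl in place of 4-bromophenyl gives a number 11 percentage points higher from compound 3 to compound 4 (beyond the scatter) in this assay, so the step seen on the core of compound 1 does not recur there. The same change therefore runs in opposite directions on the two cores and cannot be carried from one to the other as a fixed increment: the same change on two cores in this assay, a number 13.7 percentage points lower (beyond the scatter) from compound 1 to compound 2 and a number 11 percentage points higher (beyond the scatter) from compound 3 to compound 4, 24.7 percentage points apart, beyond the scatter of two such steps

Within the data shown here, this rests on only two matched pairs at a single concentration, so it shows that the outcome of this change depends on the core in these compounds, but it does not show which feature of the core is responsible or how the change would behave on any third core.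

Still open, as far as these compounds go, is whether a longer chain in the linking part of the molecule would follow the direction of the first step or that of the second. Also open, from the compounds shown here alone, is how an amine or a carboxylic acid on the aryl group would compare with the two halogenated aryl groups on either core.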